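This account rests on a few compounds, and the source may have more. Where it says the series, first, only, none or still open, it means among the compounds named here.

Four compounds share one core. Compound 1 `C=C1CCC[C@H]2[C@](C)(CC3=C(O)C(=O)C(CCCCC(C)=O)=C(OC)C3=O)[C@@H](C)CC[C@]12C` carries a 4-acetylbutyl group on a ring carbon, compound 3 `C=C1CCC[C@H]2[C@](C)(CC3=C(O)C(=O)C=C(OC)C3=O)[C@@H](C)CC[C@]12C` has hydrogen there, and compound 2 `COC(=O)c1cc(C[C@H]2C(C)=CC[C@H]3C(C)(C)CCC[C@]23C)c(O)c(O)c1O` bears a methoxycarbonyl group on its aromatic ring. In a functional assay on MCF7 cells (Homo sapiens) for antiproliferative activity, read by sulforhodamine B assay, with a stated time of 72 h (a lower number here means a stronger inhibitor, a higher number a weaker inhibitor), compound 1 reaches only the limit of > 10000 nM. Compound 3 likewise gives only the limit > 10000 nM. Compound 2 stands at the limit > 10000 nM too. Among the compounds with values here, the one measured step, a step that the two limits leave unreadable from compound 1 to compound 3, has no readable size because of the limit of > 10000 nM in this assay, at which 3 of the 3 values shown sit. Compound 4 `COC(=O)c1cc(O)c(O)c(C[C@H]2C(C)=CC[C@H]3C(C)(C)CCC[C@]23C)c1` differs from compound 2 by hydrogen in place of hydroxy on an aromatic carbon. Within the data shown here, no measured step bears on this change, so compound 4 is expected to remain at the limit, with an estimate of 15000 nM spanning 5000 nM to 50000 nM. The expected step that the limit leaves unreadable from compound 2 to compound 4 is thus none that could be read.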

Compound 4, half-maximal inhibitory concentration: > 10000 nM
Compound 4: only a limit was reported (the forecaster's own chance of this, stated with the estimate: 85%); the middle value does not contradict the limit.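

No size can be read for the change from compound 2 to compound 4, because both results are limits, not numbers: the limit of > 10000 nM in this assay, at which 4 of the 4 values shown sit.

The compounds shown leave open which structural features, if any, would bring measurable activity in this assay.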